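The source may report more compounds than this note shows. Statements on the series, on what has been measured and on what is new or still open speak of the compounds shown alone.

Compounds measured so far:
- compound 1, `CC(C)c1onc(-c2c(Cl)cccc2Cl)c1COc1ccc(-c2nc3cc(C(=O)O)ccc3n2C)cc1`, 4410 nM
- compound 2, `CC(C)c1onc(-c2c(Cl)cccc2Cl)c1COc1ccc(-c2nc3ccc(C(=O)O)cc3n2C2CCC2)cc1`, 1100 nM
- compound 3, `CC(C)c1onc(-c2c(Cl)cccc2Cl)c1COc1ccc(-c2nc3ccc(C(=O)O)cc3n2CC2CCCCC2)c(F)c1`, 840 nM

In an assay on HEK-293T cells for antagonist activity at vitamin D3 receptor (Homo sapiens), read by a luciferase reporter, with a stated time of 24 h (on this read-out lower numbers stand for stronger inhibition and higher numbers for weaker inhibition), compound 2 gives 1100 nM, the second highest of the three numbers. Its nearest neighbour is compound 3, whose 840 nM lies within the scatter of the value of compound 2, so the two cannot be told apart. Compound 1, at 4410 nM, stands beyond the scatter above compound 2. The two values differ by more than the usual scatter, and that is all the pair shows.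

Compound 4, `CCCC(CCC)n1c(-c2ccc(OCc3c(-c4c(Cl)cccc4Cl)noc3C(C)C)cc2)nc2ccc(C(=O)O)cc21`, has not yet been measured. It differs from compound 2 in one place: 1-propylbutyl in place of cyclobutyl on an aromatic nitrogen. For the measured compounds named here, no pair of measured compounds differing in only one place is available, so no measured step gives a direct guide. The values of compound 2 and compound 3 show that the two compounds carrying the larger groups on that ring nitrogen sit at the lower end of the range, while compound 1 sits higher. On that basis compound 4 is expected to come out at or somewhat below compound 2, with a step of a 1.7-fold lower number from compound 2 to compound 4 (0.23 log units; within the scatter) that is expected to be small, close to the edge of the scatter, in the direction of a lower number. Compound 4 is therefore estimated at 650 nM, within the range 220 nM to 2000 nM.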

Compound 4, half-maximal inhibitory concentration: > 10000 nM
Compound 4: a limit, no number (the forecaster's own chance of this, stated with the estimate: 5%); middle value at least 15-fold (1.18 log units) from the limit.
By their numbers in this assay, from the lowest: compounds 3 and 2 (each within the scatter of the next); then compound 1. At a limit, above all of these: compound 4.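

In this assay compound 4 gives > 10000 nM, which is a limit of the assay and not a number. Exchanging cyclobutyl for 1-propylbutyl on this aromatic nitrogen gives an at least 9.0-fold higher number from compound 2 to compound 4 (0.95 log units; beyond the scatter), the first change in a single place among these compounds, and it shows that activity here depends strongly on the group the nitrogen carries. The true size of the step remains unknown, as the reading for compound 4 marks only where the assay stops: the limit of > 10000 nM in this assay, at which 1 of the 4 values shown sits.

The change removes a four-membered ring of carbon only and brings in a chain with no ring and more carbon, and the compounds shown cannot tell whether the loss of ring or the added carbon accounts for the step. Cycloheptyl, which keeps a ring with the same carbon count as 1-propylbutyl, and isopropyl, a branched chain shorter than cyclobutyl, would separate these two readings on the same nitrogen, but neither stands among the compounds shown, so the question stays open.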